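The compounds below may be only part of what the source reports. "The series", "measured", "known", "first", "only" and "open" are said of these compounds alone.

Measured so far, in a functional assay on NCI-H322M cells (Homo sapiens) for inhibition, read by sulforhodamine B assay, with a stated time of 48 h; on this read-out higher numbers stand for lower toxicity in this test and lower numbers for higher toxicity in this test:
Compound 1, `COc1cc(-c2cc(/C=C/C(=O)c3ccc(Cl)c(Cl)c3)[nH]n2)cc(OC)c1OC`, gives > 100000 nM, which is a limit of the test rather than a number.
Compound 2, `COc1ccc(C(=O)/C=C/c2cc(-c3cc(OC)c(OC)c(OC)c3)n[nH]2)cc1OC`, gives 5510 nM.

Within the data shown here, compound 2 therefore holds the only real number among the two values shown, while compound 1 sits at the limit of > 100000 nM in this assay, at which 1 of the 2 values shown sits. Among the measured compounds shown here, the single measured step, an at least 18-fold lower number from compound 1 to compound 2 (1.25 log units; beyond the scatter), exchanged the ring on the carbonyl carbon and went well beyond the scatter. Compound 3, `COc1cc(-c2cc(/C=C/C(=O)c3ccc(F)c(F)c3)[nH]n2)cc(OC)c1OC`, makes a related exchange in the opposite sense: 3,4-difluorophenyl in place of 3,4-dimethoxyphenyl on a carbonyl carbon. The expectation rests on that one step, an at least 18-fold lower number from compound 1 to compound 2 (1.25 log units; beyond the scatter): swapping a dihalogenated ring for the dimethoxy ring lowered the number sharply, so bringing a dihalogenated ring back is expected to raise it again, probably by a large step, with a real chance that only a limit is reported. For compound 3 the estimated value is 60000 nM, ranging from 15000 nM to 200000 nM, which corresponds to an expected 11-fold higher number from compound 2 to compound 3 (1.04 log units; beyond the scatter).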

Compound 3, concentration lethal to 50% of the cells: > 100000 nM
Compound 3 gave a limit, no number; the forecaster's own chance of this, stated with the estimate: 45%; middle value at least 1.6-fold (0.22 log units) from the limit.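

Replacing the 3,4-dimethoxyphenyl on the carbonyl carbon with 3,4-difluorophenyl gives an at least 18-fold higher number from compound 2 to compound 3 (1.25 log units; beyond the scatter) in this assay. Among these compounds, the contrast with compound 2 now holds against two different dihalogenated rings rather than one, so it does not depend on 3,4-dichlorophenyl alone: of the three compounds, only the one carrying 3,4-dimethoxyphenyl gives a real number. The step between compound 1 and compound 3 cannot be read, and their two rings cannot be ranked against each other: the limit of > 100000 nM in this assay, at which 2 of the 3 values shown sit.

Nothing shown says whether a phenyl ring with a single methoxy group, or one carrying a dimethylamino group, would also give a real number. On these data alone, how far compound 1 and compound 3 lie past the limit of the test also stays open.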